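This account rests on a few compounds, and the source may have more. Where it says the series, first, only, none or still open, it means among the compounds named here.

Working notes on the series. In a functional assay on A549 cells (Homo sapiens) for antiproliferative activity, read by MTT assay, with a stated time of 72 h (a lower number here means a stronger inhibitor, a higher number a weaker inhibitor), compound 1 (`COc1cc(-c2ncnn2-c2ccc(Cl)cc2Cl)cc(OC)c1OC`) gives only a limit, > 10000 nM. Compound 2 (`COc1cc(-c2ncnn2-c2ccc(F)cc2)cc(OC)c1OC`) also gives only a limit, > 10000 nM. Compound 3 (`COc1cc(-c2ncnn2-c2ccc(N)cc2)cc(OC)c1OC`) gives only a limit too, > 10000 nM. Among the measured compounds shown here, compound 3 therefore has no number of its own, and the series so far rests on (the limit of > 10000 nM in this assay, at which 3 of the 3 values shown sit).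

Compound 4 (`COc1ccc(-n2ncnc2-c2cc(OC)c(OC)c(OC)c2)cc1`) differs from compound 3 as follows: methoxy in place of amino on an aromatic carbon. This is methoxy in place of amino on an aromatic carbon, para to a large group.

The closest measured change is a step that the two limits leave unreadable from compound 2 to compound 3, which also replaces one group with another on an aromatic carbon. The other two are a step that the two limits leave unreadable from compound 1 to compound 2 and a step that the two limits leave unreadable from compound 1 to compound 3. None of the three has a readable size, so they support no expected direction and no expected step beyond the scatter.

The expected step, a number no higher from compound 3 to compound 4 (the limit leaves the size open), is an estimate that stays close to the limit. Compound 4 is expected at about 10000 nM, with an estimated range of 1500 nM to 30000 nM, and it may well return only a limit.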

Compound 4, half-maximal inhibitory concentration: > 10000 nM
Compound 4 was reported as a limit (the forecaster's own chance of this, stated with the estimate: 60%); the middle value lies on the limit itself.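

In this assay, among the compounds shown here, compound 4 also gives only a limit, so no step among compound 1, compound 2, compound 3 and compound 4 can be read, and the series still rests on a single limit: the limit of > 10000 nM in this assay, at which 4 of the 4 values shown sit. The compounds shown leave open whether any of these substituted phenyl groups on the shared core gives a measurable value in this assay, and how far such values would differ.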